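A few compounds are considered here, and "the series" means these few. Any claim that something is new, unique, unknown or untested is made for them only; others in the source may bear on it.

For the measured compounds named here, in a functional assay on the whole organism for activation, with Mus musculus as the target (a higher number here means that more compound is needed for the effect, a lower number that less compound is needed), compound 2 `CCc1nc(N)c2nc(O)n(Cc3ccccc3)c2n1` gives 3 mg/kg, and this is the only plain number available. Compound 1 `Nc1nc(SCc2ccccc2)nc2c1nc(O)n2Cc1ccccc1` gives > 1 mg/kg in this assay, which is a limit of the assay and not a number. The step that the limit leaves unreadable from compound 1 to compound 2 therefore has no readable size because the limit of > 1 mg/kg in this assay, at which 1 of the 2 values shown sits, hides it.

Compound 3 `COc1nc(N)c2nc(O)n(Cc3ccccc3)c2n1` differs from compound 2 by methoxy in place of ethyl on an aromatic carbon. Going by the values given here, no measured step bears on this exchange, since the single step available is unreadable, so the change offers no guide in either direction. The step of no change at the digits printed from compound 2 to compound 3 (within the scatter) is therefore expected to stay within the usual scatter of this assay. Compound 3 is estimated to give 3 mg/kg in this assay, with a likely range from 1 mg/kg to 10 mg/kg, and the chance that only a limit is reported remains real.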

Compound 3, minimum effective dose: > 1 mg/kg
Compound 3: a limit, no number (the forecaster's own chance of this, stated with the estimate: 25%); the middle value lies beyond the limit too.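

Neither step to compound 3, from compound 2 or from compound 1, can be read, because both run into the same limit: the limit of > 1 mg/kg in this assay, at which 2 of the 3 values shown sit.

The compounds shown leave open whether compound 1 or compound 3 needs more or less compound than compound 2 in this assay.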